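A few compounds are considered here, and "the series" means these few. Any claim that something is new, unique, unknown or untested is made for them only; others in the source may bear on it.

Measured compounds:

Compound 1, `O=c1[nH]cnc2c1c(-c1ccoc1)cn2[C@@H]1O[C@H](CO)[C@@H](O)[C@H]1O`: in a functional assay on A549 cells (Homo sapiens), read by MTT assay, with a stated time of 72 h (a lower number here means a stronger inhibitor, a higher number a weaker inhibitor), compound 1 gives > 20000 nM, which is a limit of the assay and not a number.

Compound 2, `O=c1[nH]cnc2c1c(-c1cccs1)cn2[C@@H]1O[C@H](CO)[C@@H](O)[C@H]1O`: in this assay compound 2 gives > 20000 nM, again a limit.

Compound 3, `O=c1[nH]cnc2c1c(-c1ccco1)cn2[C@@H]1O[C@H](CO)[C@@H](O)[C@H]1O`: in this assay compound 3 gives > 20000 nM, also a limit.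

Among the compounds with values here, compound 3 therefore stands where every value so far stands: at the limit of > 20000 nM in this assay, at which 3 of the 3 values shown sit. Nothing places it above or below its two companions.

Compound 4, `Nc1nc2c(c(-c3ccco3)cn2[C@@H]2O[C@H](CO)[C@@H](O)[C@H]2O)c(=O)[nH]1`, differs from compound 3 by amino in place of hydrogen on an aromatic carbon.

The measured steps all swap one five-membered heteroaryl ring for another and none touches the place now changed. Each is hidden by the limits: a step that the two limits leave unreadable from compound 1 to compound 2, a step that the two limits leave unreadable from compound 1 to compound 3 and a step that the two limits leave unreadable from compound 2 to compound 3. They give no reading of how this assay answers any change on the shared core, so no step beyond the scatter can be expected in either direction from this evidence, and the most likely outcome for compound 4 is another limit. The step from compound 3 to compound 4 is estimated at a step that the limit leaves unreadable from compound 3 to compound 4. Compound 4 is expected at 30000 nM, ranging from 8000 nM to 120000 nM.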

Compound 4, half-maximal inhibitory concentration: > 20000 nM
Compound 4 was reported as a limit; the forecaster's own chance of this, stated with the estimate: 80%; the middle value does not contradict the limit.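

In this assay, within the data shown here, compound 4 gives > 20000 nM which, like the result for compound 3, is a limit and not a number, so no step between these two compounds can be read: the limit of > 20000 nM in this assay, at which 4 of the 4 values shown sit.

The compounds shown leave open how amino in place of hydrogen changes potency, and whether any change on the shared core gives a readable value in this assay at all.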